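The source may hold more compounds than are shown below. What is called first, only, known or untested is meant among the compounds shown, and "the series" means these compounds.

Series notes. Compound 1 `O=C1CCC2(c3ccc(Cl)cc3)OCCCN12` is the ring-closed member; in a functional assay on the whole organism with Mus musculus as the target (on this read-out higher numbers stand for an effect only at larger amounts of compound and lower numbers for an effect already at smaller amounts), compound 1 gives 91.7 mg/kg. Compound 2 `O=C(CCC(=O)c1ccc(Cl)c(Cl)c1)NCCCO` and compound 3 `O=C(CCC(=O)c1ccc(Cl)cc1)NCCCO` are open-chain amides. In this assay compound 2 reaches only a limit, > 600 mg/kg. In this assay compound 3 likewise reaches only a limit, > 300 mg/kg. The step between them, a step that the two limits leave unreadable from compound 2 to compound 3, has no readable size because the limit of > 600 mg/kg in this assay, at which 1 of the 3 values shown sits, and the limit of > 300 mg/kg in this assay, at which 1 of the 3 values shown sits, bound both ends. Compound 3 therefore stands at a limit, with no number of its own among the three values shown. Compound 4 `Cc1ccc(C(=O)CCC(=O)NCCCO)cc1` differs by methyl in place of chloro on an aromatic carbon. Going by the values given here, no measured step with a readable size bears on this change, so no direction can be derived from the series. The expectation for compound 4 in this assay is 400 mg/kg, within 150 mg/kg to 1200 mg/kg, most likely again reported as a limit. The expected step, a step that the limit leaves unreadable from compound 3 to compound 4, is estimated to stay within the scatter.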

Compound 4, dose for half-maximal effect: > 300 mg/kg
Compound 4: a limit, no number; the forecaster's own chance of this, stated with the estimate: 70%; the middle value does not contradict the limit.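

Compound 3 and compound 4 both stand at a limit in this assay, so no step can be read between them: the limit of > 300 mg/kg in this assay, at which 2 of the 4 values shown sit.

The compounds shown leave open whether methyl in place of chloro changes the dose for half-maximal effect at all.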